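Trimming an Oxime Ether Substituent to a Nitrile

The compounds below may be only part of what the source reports. "The series", "measured", "known", "first", "only" and "open" are said of these compounds alone.

Measured compounds:
compound 1 `COC(=O)c1cc(CO/N=C(\C)c2ccc(Sc3cc(F)cc(C4CCOCC4)c3)cc2)on1`: 100 nM
compound 2 `COC1(c2cc(F)cc(Sc3ccc4c(c3)OCC/C4=N\OCC#N)c2)CCOCC1`: 40 nM

In a functional assay (blood) for inhibition, with Homo sapiens as the target (on this read-out higher numbers stand for weaker inhibition and lower numbers for stronger inhibition), compound 1 gives 100 nM, the highest of the two numbers recorded. Its nearest neighbour is compound 2, which in this assay gives 40 nM, a lower number by a margin that lies beyond the usual scatter. Among the measured compounds shown here, compound 2 differs from compound 1 in several places at once, so no single-change step between measured compounds is available.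

Compound 3 `C/C(=N\OCC#N)c1ccc(Sc2cc(F)cc(C3CCOCC3)c2)cc1` is the unmeasured member. It keeps the core of compound 1 and alters only the oxime ether, where the change is cyano in place of 3-(methoxycarbonyl)-1,2-oxazol-5-yl on a saturated chain carbon bound to an oxygen on an unsaturated carbon. Compound 3 thereby carries a cyanomethoxy group, the same group found on the oxime of compound 2. Given that compound 2 reaches 40 nM with this group, compound 3 is expected to move to a somewhat lower number than compound 1, though not by much more than the scatter. The expected step is a 1.7-fold lower number from compound 1 to compound 3 (0.22 log units; within the scatter). The estimate for compound 3 in this assay is therefore 60 nM, within a range of 20 nM to 200 nM.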

Compound 3, half-maximal inhibitory concentration: 20 nM
Beside the measured number, compound 3's estimate is 3.0-fold (0.48 log units) above it; the measured number falls inside the stated range.
By their numbers in this assay, from the lowest: compounds 3 and 2 (each within the scatter of the next); then compound 1.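

Among the compounds shown here, the change of 3-(methoxycarbonyl)-1,2-oxazol-5-yl to cyano, on a saturated chain carbon bound to an oxygen on an unsaturated carbon, gives in this assay a 5.0-fold lower number from compound 1 to compound 3 (0.70 log units; beyond the scatter), the only single-change step in this set. It shows that this place on the oxime ether can be altered on its own with an effect beyond the scatter, and that the substituent of 9 heavy atoms with its five-membered aromatic ring is not required for inhibition at this level, as the cyano group, with 2 heavy atoms and no ring, gives the lower number on the same core. No measurement given here bears on why the number falls.

The compounds shown leave open whether the cyano group itself matters or only the loss of the 3-(methoxycarbonyl)-1,2-oxazol-5-yl, and how a methyl, a primary amide or a longer chain such as cyanoethyl would read at this place. They also leave open whether the step carries over to other cores, as the cyanomethoxy group of compound 2 stands on a structure that differs from compound 3 in several places.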